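This account rests on a few compounds, and the source may have more. Where it says the series, first, only, none or still open, it means among the compounds named here.

Of the compounds shown here, three share one core and have been tested in a functional assay on the whole organism (strain Wistar) with Rattus norvegicus as the target, with a stated time of 15 days, at a dose of 100 mg/kg by the oral route; a lower number here means a weaker effect, a higher number a stronger effect of the compound at the dose given. Compound 1, with the structure `Cc1nc(COc2ccc(/C=C3\SC(=O)NC3=O)cc2)cs1`, gives 38.9% in this assay. Compound 2, with the structure `COc1ccc(-c2nnc(SCCOc3ccc(/C=C4\SC(=O)NC4=O)cc3)[nH]2)cc1`, gives 71.2% in this assay. Compound 3, with the structure `O=C1NC(=O)/C(=C/c2ccc(OCCSc3nnc(-c4ccccc4)o3)cc2)S1`, gives 33.1% in this assay.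

On these numbers compound 3 sits at the low end of the three. Its gap to compound 1 is within the usual scatter of such measurements, so those two cannot be told apart with confidence. Its gap to compound 2 is beyond the scatter, so compound 2 is clearly the stronger of that pair.

Compound 4, with the structure `O=C1NC(=O)/C(=C/c2ccc(OCCSc3nnc(-c4ccncc4)o3)cc2)S1`, has not yet been measured. It differs from compound 3 in one place: pyridin-4-yl in place of phenyl on an aromatic carbon

Within the data shown here, no pair of measured compounds shows a change of this kind, so nothing here tells how large its effect may be. In the absence of such a comparison, the step from compound 3 to compound 4 is expected to be small, around a number 4.9 percentage points higher from compound 3 to compound 4 (within the scatter), which is within the scatter in either direction. Compound 4 is therefore estimated to give 38% in this assay, with a likely range from 20% to 60%.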

Compound 4, a percentage reported as activity, at one dose (the size of the read-out at that dose, not a potency): 69.7%
Compound 4: middle estimate off by 31.7 percentage points, on the low side; the whole stated range lies below it.
By their numbers in this assay, from the lowest: compounds 3 and 1 (each within the scatter of the next); then compounds 4 and 2 (each within the scatter of the next).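

Putting pyridin-4-yl in place of phenyl on the five-membered aromatic ring gives a number 36.6 percentage points higher from compound 3 to compound 4 (beyond the scatter) in this assay, so what this position carries clearly matters. The two groups have the same number of heavy atoms and differ in one ring nitrogen, which adds a hydrogen-bond acceptor, yet that small edit produces a step beyond the scatter. This is the only pair shown that differs in one place, and it gives the one direct reading of how far a single change can move this whole-animal read-out, but no measurement shown accounts for the step.

The compounds shown leave open whether the location of the ring nitrogen matters, since pyridin-3-yl and pyridin-2-yl are absent, and whether a phenyl ring carrying an amine or a carboxylic acid at this position would give a similar result. From the compounds shown here alone, each read-out also comes from a single oral dose, so it remains open how compound 3 and compound 4 would compare at other doses, and whether the same swap would have a similar effect on a different linker or ring.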